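The source may hold more compounds than are shown below. What is called first, only, known or untested is meant among the compounds shown, and "the series" means these compounds.

Compound 1, with the structure `CCCCCCCCCCCCCCCCc1c(C)c(N(C)C)nc(C)c1O`, was tested in a functional assay on cells (Lymphocyte, Homo sapiens) for inhibition, read by flow cytometry, using a membrane potential dye, with a stated time of 16 h, tested at 100 nM; on this read-out higher numbers stand for a stronger effect at the one concentration tested and lower numbers for a weaker effect. In this assay compound 1 gives 62%. Compound 2, `CCCCCCCCCCCCCCCCCCCc1c(C)c(N(C)C)nc(C)c1O`, carries a longer chain, and in this assay compound 2 gives 23%. The change from compound 2 to compound 1 is hydrogen in place of propyl on a saturated chain carbon, ten or more bonds along the chain from an aromatic carbon, and it made a step of a number 39 percentage points higher from compound 2 to compound 1 (beyond the scatter).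

Compound 3, `CCCCCCCCCCCCCCCCCCCc1nc(N(C)C)c(C)c(C)c1O`, has the same atoms as compound 2 joined differently; how the two cores differ is not broken down here. In this assay compound 3 gives 24%, a number that sits within the scatter of the number for compound 2.

Compound 4, `CCCCCCCCCCCCCCCCc1nc(N(C)C)c(C)c(C)c1O`, relates to compound 3 the way compound 1 relates to compound 2: the change is hydrogen in place of propyl on a saturated chain carbon, ten or more bonds along the chain from an aromatic carbon, the same change at the same place. Since compound 3 starts from a number close to that of compound 2, and the earlier step was a number 39 percentage points higher from compound 2 to compound 1 (beyond the scatter), a step of about a number 34 percentage points higher from compound 3 to compound 4 (beyond the scatter) is expected from compound 3 to compound 4. The activity of compound 4 in this assay is thus estimated at 58%, most likely between 38% and 76%.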

Compound 4, a percentage reported as activity, at one concentration (the size of the read-out at that concentration, not a potency): 67%
Estimate against measurement, compound 4: 9 percentage points below, within the range that was stated.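

Replacing propyl with hydrogen on a saturated chain carbon gave in this assay a step of a number 43 percentage points higher from compound 3 to compound 4 (beyond the scatter). Among these compounds, this is one pair on each of only two cores, and each number comes from a single concentration, so it shows neither how far the pattern extends to other cores nor how potency itself changes, and it gives no reason for the step. Within these four compounds, however, the change carries from one core to the other with its size kept, so the step measured on the first core was a fair guide to the second: the same change on two cores in this assay, a number 39 percentage points higher (beyond the scatter) from compound 2 to compound 1 and a number 43 percentage points higher (beyond the scatter) from compound 3 to compound 4, 4 percentage points apart, within the scatter of two such steps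

The compounds shown span just two chain lengths, so they leave open how the read-out would respond to a shorter chain such as hexyl, or to a longer chain than either. They also leave open what a chain bearing an amine or a carboxylic acid would do on either core.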